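This account rests on a few compounds, and the source may have more. Where it says the series, first, only, none or still open, it means among the compounds named here.

Of the compounds shown here, two of a shared core have been measured, and a third awaits its result. Compound 1 `CC(C)[C@H](NC(=O)COc1cccc2ccccc12)C(=O)N[C@@H](CC(=O)O)C(=O)CSc1nnnn1-c1ccccc1` gives 153000 nM in a functional assay on Jurkat cells (Homo sapiens) for inhibition; on this read-out higher numbers stand for weaker inhibition and lower numbers for stronger inhibition. Compound 2 `CC(C)[C@H](NC(=O)COc1cccc2ccccc12)C(=O)N[C@@H](CC(=O)O)C(=O)COc1ccccn1` differs from it by an at least 1.3-fold higher number from compound 1 to compound 2 (0.11 log units; that floor lies within the scatter). In this assay compound 2 gives > 200000 nM, which is a limit of the assay and not a number, as the limit of > 200000 nM in this assay, at which 1 of the 2 values shown sits, records. Compound 2 therefore stands at the weak end of what has been measured, with its true value not pinned down.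

Compound 3 `CC(C)[C@H](NC(=O)COc1cccc2ccccc12)C(=O)N[C@@H](CC(=O)O)C(=O)COc1cc(C(F)(F)F)ncn1` changes compound 2 by 6-(trifluoromethyl)pyrimidin-4-yl in place of pyridin-2-yl on an oxygen on a saturated carbon. For the measured compounds named here, no measured step covers this exchange; the one step measured, from compound 1 to compound 2, concerns a different group at a neighbouring place and was small enough to lie within the usual scatter. With compound 2 already at the limit, the change offers no measured ground for a large shift in either direction, so the expected step in this assay is a number no higher from compound 2 to compound 3 (the limit leaves the size open). Compound 3 is thus estimated at 200000 nM, with a likely range from 60000 nM to 700000 nM, and a fair chance that the assay again reports only a limit.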

Compound 3, half-maximal inhibitory concentration: > 200000 nM
Compound 3: a limit, no number; the forecaster's own chance of this, stated with the estimate: 60%; the middle value lies on the limit itself.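

In this assay compound 3 gives > 200000 nM, which is a limit of the assay and not a number, so a second aromatic ring on this oxygen also yields no readable value: the limit of > 200000 nM in this assay, at which 2 of the 3 values shown sit.

The step from pyridin-2-yl to 6-(trifluoromethyl)pyrimidin-4-yl cannot be read, since both ends of it are limits, and the added ring nitrogen and the three fluorine atoms therefore cannot be credited with any effect, in either direction. Measured against the (1-phenyl-1H-tetrazol-5-yl)sulfanyl group, the new (6-(trifluoromethyl)pyrimidin-4-yl)oxy group gives an at least 1.3-fold higher number from compound 1 to compound 3 (0.11 log units; that floor lies within the scatter), so this exchange shows no step beyond the usual scatter.

From the compounds shown here alone, how far compound 2 and compound 3 truly lie from each other stays open, as does whether either of them has any real inhibition in this assay at all. What a different group would do at this place, such as an amine or a plain phenoxy group, also stays open, since the compounds shown say nothing about either.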